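A few compounds are considered here, and "the series" means these few. Any claim that something is new, unique, unknown or untested is made for them only; others in the source may bear on it.

Working notes on the series. The compounds share the core shown in compound 1 `Cc1ccccc1-c1nn(-c2ccccc2Cl)cc1CNCCN1CCN(C)CC1` and differ only in the aryl group on the aromatic nitrogen. In an ADME assay on Huh-7 cells (Homo sapiens) for cytotoxicity (on this read-out lower numbers stand for higher toxicity in this test and higher numbers for lower toxicity in this test), compound 1 reports a limit of the assay rather than a number, > 20000 nM; compound 1 thus sits at the limit of > 20000 nM in this assay, at which 1 of the 3 values shown sits. Compound 2 `Cc1ccccc1-c1nn(-c2ccc(C(F)(F)F)cc2)cc1CNCCN1CCN(C)CC1` gives in this assay 11000 nM, and compound 3 `Cc1ccccc1-c1nn(-c2ccc(OC(F)(F)F)cc2)cc1CNCCN1CCN(C)CC1` gives 17000 nM. Compound 3 stands at the top of the two numbers available, with compound 2 nearest, the gap being a 1.5-fold higher number from compound 2 to compound 3 (0.19 log units; within the scatter). Against compound 1 only floors can be read: an at least 1.8-fold lower number from compound 1 to compound 2 (0.25 log units; that floor lies within the scatter) and an at least 1.1-fold lower number from compound 1 to compound 3 (0.07 log units; that floor lies within the scatter).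

Compound 4 `Cc1ccccc1-c1nn(-c2ccc([N+](=O)[O-])cc2)cc1CNCCN1CCN(C)CC1` differs from compound 3 by nitro in place of trifluoromethoxy on an aromatic carbon. The measured step that bears on this change most directly is the exchange of one group for another on the same aromatic carbon, a 1.5-fold higher number from compound 2 to compound 3 (0.19 log units; within the scatter), which stayed inside the scatter; the two steps from compound 1 set only floors that also lie inside the scatter. None of the three steps therefore supports a shift beyond the scatter for this kind of change. For compound 4 in this assay the expected step is accordingly a 1.1-fold lower number from compound 3 to compound 4 (0.05 log units; within the scatter). Compound 4 is estimated at 15000 nM, in a range from 7000 nM to 30000 nM.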

Compound 4, half-maximal cytotoxic concentration: > 20000 nM
Compound 4: no number, only a limit (the forecaster's own chance of this, stated with the estimate: 30%); at least 1.3-fold (0.12 log units) between middle value and limit.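

With compound 4, a second value in this assay is a limit of the assay rather than a number: the limit of > 20000 nM in this assay, at which 2 of the 4 values shown sit.

Nitro on this aromatic carbon, para to a large group, therefore adds only floors to the series, an at least 1.1-fold higher number from compound 3 to compound 4 (0.07 log units; that floor lies within the scatter) and an at least 1.8-fold higher number from compound 2 to compound 4 (0.25 log units; that floor lies within the scatter), so neither exchange is shown to move the read-out beyond the scatter. Across trifluoromethyl, trifluoromethoxy and nitro at this position, in compound 2, compound 3 and compound 4, no step is printed as beyond the scatter, although nitro differs from the other two groups in its atoms and its count of hydrogen-bond acceptors; the step between compound 1 and compound 4 cannot be read, as both report limits.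

On these data alone, the true size of the nitro change stays open, as the floors give only a lower bound for it, and they do not settle whether compound 4 differs from compound 3 or compound 2 at all. Also open, as far as these compounds go, is whether an amine or a carboxylic acid on this same aromatic carbon would keep the read-out within the scatter of these three compounds.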